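A few compounds are considered here, and "the series" means these few. Any claim that something is new, unique, unknown or untested is made for them only; others in the source may bear on it.

Measured so far:
compound 1 `CCN1CCc2c(sc(NC(=O)[C@@H]3CCCN3)c2C(N)=O)C1` — > 25000 nM
compound 2 `CC(C)(C)C[N+]1(C)CCc2c(sc(NC(=O)Nc3ccc(Cl)cc3)c2C(N)=O)C1` — 290 nM
compound 3 `CC(C)(C)OC(=O)CN1CCc2c(sc(NC(=O)Nc3ccc(Cl)cc3)c2C(N)=O)C1` — > 25000 nM

In a functional assay (strain AB) with Danio rerio as the target, read by microscopy, with a stated time of 1 h (on this read-out lower numbers stand for an effect already at smaller amounts and higher numbers for an effect only at larger amounts of compound), compound 1 gives only a limit, > 25000 nM, not a number. Compound 3 likewise returns only a limit, > 25000 nM. Among the measured compounds shown here, compound 2 is the one compound of the three that yields a number, 290 nM, and so stands alone as the single measured point in this assay. Two of the three values sit at the limit of > 25000 nM in this assay, at which 2 of the 3 values shown sit.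

Compound 4 `CC(C)(C)OC(=O)CCC[N+]1(C)CCc2c(sc(NC(=O)Nc3ccc(Cl)cc3)c2C(N)=O)C1` is not yet measured. It differs from compound 2 in one place: 2-(tert-butoxycarbonyl)ethyl in place of tert-butyl on a saturated chain carbon bound to an amine nitrogen in a ring. The shared core, the quaternary ring nitrogen and the chlorophenyl urea are kept.

For the measured compounds named here, no step between measured compounds is known, so the size of the step from compound 2 to compound 4 cannot be read from the data. Going by the values given here, compound 4 carries an ester chain like compound 3, which sits at a limit, but that pair differs in more than one place and no step exists for it. The expectation is a loss in this assay, beyond the scatter: compound 4 is estimated at 1500 nM, between 300 nM and 8000 nM. That estimated step is a 5.2-fold higher number from compound 2 to compound 4 (0.71 log units; beyond the scatter).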

Compound 4, half-maximal effective concentration: 250 nM
Compound 4: middle estimate off by 6.0-fold (0.78 log units), on the high side, outside the stated range (below it).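

In this assay, 2-(tert-butoxycarbonyl)ethyl in place of tert-butyl on a saturated chain carbon bound to an amine nitrogen in a ring gives a 1.2-fold lower number from compound 2 to compound 4 (0.06 log units; within the scatter) and the two compounds cannot be told apart. Among the compounds shown here, this is the first step read at this position, and it shows that a group of 9 heavy atoms with 2 hydrogen-bond acceptors can stand where one of 4 heavy atoms with none stood, with the quaternary ring nitrogen and the chlorophenyl urea kept. Nothing measured in the compounds shown accounts for this result.

From the compounds shown here alone, whether a carboxylic acid in place of the tert-butyl ester, a terminal amine or a longer chain would hold the read-out stays open. A single step gives no trend along the chain, and steps to the other compounds cannot be read.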